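The compounds below may be only part of what the source reports. "The series", "measured", "known", "first", "only" and "open" are said of these compounds alone.

Compound 1 `COc1ccc(-c2cc(/C=C/C(=O)c3ccc(N)cc3)[nH]n2)cc1` gives 3480 nM in a functional assay on SF-539 cells (Homo sapiens) for inhibition, read by sulforhodamine B assay, with a stated time of 48 h; a lower number here means a stronger inhibitor of growth, a higher number a weaker inhibitor of growth. Compound 2 `COc1cc(-c2cc(/C=C/C(=O)c3ccc(Cl)c(Cl)c3)[nH]n2)cc(OC)c1OC` gives 18700 nM. Compound 3 `COc1cc(-c2cc(/C=C/C(=O)c3ccc(F)c(F)c3)[nH]n2)cc(OC)c1OC` gives 17700 nM.

On these numbers compound 1 stands lowest, with compound 3 and compound 2 both well beyond the scatter above it. Among the measured compounds shown here, the only single step among the measured compounds is a 1.1-fold lower number from compound 2 to compound 3 (0.02 log units; within the scatter), a change on the carbonyl side that says nothing about the aryl ring carried by the core of compound 1. Compound 4 `COc1ccc(-c2cc(/C=C/C(=O)c3ccc(N)cc3)[nH]n2)cc1OC` differs from compound 1 by methoxy in place of hydrogen on an aromatic carbon. For the measured compounds named here, no measured step bears on this change, so no shift beyond the scatter is expected in this assay: the estimated step is a 1.1-fold higher number from compound 1 to compound 4 (0.06 log units; within the scatter). Compound 4 is therefore expected to give about 4000 nM, within 1500 nM to 12000 nM.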

Compound 4, concentration for total growth inhibition: 3530 nM
Estimate against measurement, compound 4: 1.1-fold (0.05 log units) above, and the stated range covers the measured number.
By their numbers in this assay, from the lowest: compounds 1 and 4 (each within the scatter of the next); then compounds 3 and 2 (each within the scatter of the next).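

In this assay, among the compounds shown here, the step gives a 1.0-fold higher number from compound 1 to compound 4 (0.01 log units; within the scatter) and is the first measured change on the aryl ring carried by the core of compound 1. It shows that methoxy can enter on this aromatic carbon, ortho to a methoxy group, without moving the number beyond the scatter. No measured evidence accounts for this result.

From the compounds shown here alone, whether hydroxy or ethoxy on the same carbon would also leave the number within the scatter remains open. So does whether fluorine or a nitrile there would do so.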